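A few compounds are considered here, and "the series" means these few. Any claim that something is new, unique, unknown or untested is made for them only; others in the source may bear on it.

Three compounds have so far been measured in a functional assay on the whole organism for inhibition, with Rattus norvegicus as the target, read by paw edema; a higher number here means that more compound is needed for the effect, a lower number that less compound is needed:

compound 1, `O=C(O)c1ccc(-c2cscn2)cc1O`, gives 70 mg/kg;
compound 2, `O=C(O)c1cc(-c2ncccn2)ccc1O`, gives 100 mg/kg;
compound 3, `O=C(O)c1cc(-c2cscn2)ccc1O`, gives 95 mg/kg.

On these numbers compound 3 holds the second highest value of the three, but this says little: its nearest neighbour is compound 2 and its furthest is compound 1, and both gaps lie within the usual scatter of repeated measurements, so the three compounds cannot be told apart. Among the compounds with values here, no step between two measured compounds that differ in a single place is available here.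

The next compound, compound 4, `O=C(O)c1cc(-c2cc[nH]n2)ccc1O`, differs from compound 3 by a single change: 1H-pyrazol-3-yl in place of 1,3-thiazol-4-yl on an aromatic carbon. Within the data shown here, the measured set gives no step of this kind, so the account can only say that nothing in it points to a large move in either direction. Compound 4 is therefore expected to land close to compound 3, with the step of no change at the digits printed from compound 3 to compound 4 (within the scatter) estimated to stay within the scatter. The estimate for compound 4 in this assay is 95 mg/kg, with a range from 50 mg/kg to 180 mg/kg.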

Compound 4, dose for half-maximal effect: > 250 mg/kg
Compound 4 was reported as a limit (the forecaster's own chance of this, stated with the estimate: 10%); at least 2.6-fold (0.42 log units) between middle value and limit.
By their numbers in this assay, from the lowest: compounds 1, 3 and 2 (each within the scatter of the next). At a limit, above all of these: compound 4.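

Within the data shown here, at the aromatic carbon para to a hydroxy group and meta to a carboxy group, the earlier compounds offered no step, but in this assay this position now gives one: 1H-pyrazol-3-yl in place of 1,3-thiazol-4-yl yields an at least 2.6-fold higher number from compound 3 to compound 4 (0.42 log units; beyond the scatter), beyond the scatter. The result therefore shows that this position is not indifferent to the choice between two five-membered aromatic rings of equal heavy-atom count, which differ in sulfur against a second nitrogen and in the hydrogen-bond donor that only 1H-pyrazol-3-yl carries. Compound 4 is known here only through a limit: the limit of > 250 mg/kg in this assay, at which 1 of the 4 values shown sits.

The compounds shown cannot separate the contribution of the ring nitrogen from that of the hydrogen on it, and a 1-methyl-1H-pyrazol-3-yl group at this position would address that question. From the compounds shown here alone, how far the true value of compound 4 lies past its limit also stays open.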